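A Fluorophenyl Amide Gives Way to a tert-Butyl Isoxazole

This account rests on a few compounds, and the source may have more. Where it says the series, first, only, none or still open, it means among the compounds named here.

Two compounds carry numbers in an assay on isolated protein for inhibition of Rho-associated protein kinase 1 (Homo sapiens), read by scintillation counting, radiometric assay and 33P incorporation, with a stated time of 40 min, in the presence of a further agent that is not named here; on this read-out lower numbers stand for stronger inhibition and higher numbers for weaker inhibition. Compound 1 `COc1cc(OCC(=O)Nc2cccc(NC(=O)c3ccc(N(C)C)cc3)c2)ccc1C=O` gives 3740 nM, while compound 2 `O=C(COc1ccc2c(=O)ccoc2c1)Nc1cccc(NC(=O)c2ccc(F)cc2)c1` gives 129 nM, the lower of the two numbers, with compound 1 standing higher by a gap beyond the usual scatter. Going by the values given here, compound 3 `CC(C)(C)c1cc(C(=O)Nc2cccc(NC(=O)COc3ccc4c(=O)ccoc4c3)c2)no1` has no measurement yet. It differs from compound 2 in one place: 5-(tert-butyl)-1,2-oxazol-3-yl in place of 4-fluorophenyl on a carbonyl carbon. Among the compounds with values here, no measured pair shows this change, so its size cannot be read from the data. The account expects a small shift towards a higher number, around the edge of the scatter, as the estimated step of a 1.9-fold higher number from compound 2 to compound 3 (0.29 log units; within the scatter). For compound 3 the estimate in this assay is 250 nM, with a range from 60 nM to 1000 nM.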

Compound 3, half-maximal inhibitory concentration: 101 nM
Estimate against measurement, compound 3: 2.5-fold (0.39 log units) above, within the range that was stated.
By their numbers in this assay, from the lowest: compounds 3 and 2 (each within the scatter of the next); then compound 1.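

In this assay, the first step read at this position, on a carbonyl carbon, shows that the two groups cannot be told apart: a 1.3-fold lower number from compound 2 to compound 3 (0.11 log units; within the scatter). A five-membered aromatic ring with 2 hetero atoms and a tert-butyl group thus stands in for the 4-fluorophenyl ring with no change beyond the scatter. No available evidence explains this result.

The compounds shown leave open whether the tert-butyl group itself matters. From the compounds shown here alone, a methyl group or an amine in its place on the same ring remains untested here.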